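Shortening the ethyl group to methyl in the series

The source may hold more compounds than are shown below. What is called first, only, known or untested is meant among the compounds shown, and "the series" means these compounds.

Among the compounds with values here, in an ADME assay on microsomes from liver (Homo sapiens) for metabolic stability, read by LC-MS, using NADPH, with stated times of 10 min and 30 min (a lower number here means slower removal, a higher number faster removal of the compound), compound 2 (`CCC1c2cc(Cl)ccc2C(=O)N1c1cccnc1`) gives 6.6 mL/min/kg, the only true number so far. Compound 1 (`O=C1c2cc(F)c(Cl)cc2CCN1c1cccnc1`) reads < 3.5 mL/min/kg, which is a limit of the assay and not a number.

The next analogue is compound 3 (`CC1c2cc(Cl)ccc2C(=O)N1c1cccnc1`), where ethyl becomes methyl: hydrogen in place of methyl on a saturated chain carbon bound to a saturated ring carbon. This places hydrogen in place of methyl on a saturated chain carbon bound to a saturated ring carbon. Within the data shown here, no measured pair isolates this change, so the expectation starts from compound 2 at 6.6 mL/min/kg and is only tentative. A small move towards slower removal is expected in this assay, probably no larger than the usual scatter of repeats. The expected change is a 1.4-fold lower number from compound 2 to compound 3 (0.14 log units; within the scatter). For compound 3 the estimated clearance is 4.8 mL/min/kg, with an expected range of 3.5 mL/min/kg to 8 mL/min/kg.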

Compound 3, clearance: 12.2 mL/min/kg
Beside the measured number, compound 3's estimate is 2.5-fold (0.41 log units) below it; the whole stated range lies below it.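

Hydrogen in place of methyl on a saturated chain carbon bound to a saturated ring carbon gives, in this assay, a 1.8-fold higher number from compound 2 to compound 3 (0.27 log units; within the scatter). This is the only step shown that changes a single place, and at this place it does not separate ethyl from methyl in this read-out. Nothing given here accounts for the size of this step.

Compound 1 gives < 3.5 mL/min/kg, which is a limit of the assay and not a number, and as it differs from the other two compounds in more than one place, it adds nothing about this position. As far as these compounds go, whether a longer chain, such as propyl, or a polar group, such as an amine or a carboxylic acid, at this place would give a step beyond the scatter remains open.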